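This account rests on a few compounds, and the source may have more. Where it says the series, first, only, none or still open, it means among the compounds named here.

Compound 1 `Cc1cccc(-n2cc(-c3ccc(/C=C4\C(=O)Nc5ccccc54)cc3)nn2)c1`: 4690 nM
Compound 2 `O=C1Nc2ccc(F)cc2C1=Cc1ccc(-c2cn(-c3ccccc3)nn2)cc1`: 11100 nM
Compound 3 `Cc1ccc(-n2cc(-c3ccc(/C=C4\C(=O)Nc5ccc(F)cc54)cc3)nn2)cc1`: 34600 nM

All three were read in a functional assay on MKN-45 cells (Homo sapiens) for inhibition, read by CCK-8 assay, with a stated time of 24 h; on this read-out lower numbers stand for stronger inhibition and higher numbers for weaker inhibition. Compound 3 has the highest number of the three, beyond the scatter from both others, so it is the weakest here. Compound 4 `O=C1Nc2ccc(F)cc2/C1=C/c1ccc(-c2cn(-c3ccc(Cl)c(C(F)(F)F)c3)nn2)cc1` keeps the core of compound 3 and carries 4-chloro-3-(trifluoromethyl)phenyl in place of 4-methylphenyl on an aromatic nitrogen. Among the measured compounds shown here, no measured pair isolates a single change, so the expectation is loose. With compound 3 at 34600 nM, the top of the measured range, a move toward lower numbers is the likelier direction. The expected step in this assay is a 3.8-fold lower number from compound 3 to compound 4 (0.58 log units; beyond the scatter), moderate and toward stronger inhibition. For compound 4 the estimated value is 9000 nM, with an expected range of 2000 nM to 36000 nM.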

Compound 4, half-maximal inhibitory concentration: > 20000 nM
Compound 4: a limit, no number; the forecaster's own chance of this, stated with the estimate: 10%; middle value at least 2.2-fold (0.34 log units) from the limit.
By their numbers in this assay, from the lowest: compound 1; then compound 2; then compound 3.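

Compound 4 gives [ > 20000 nM ], a limit and not a number, so the step from compound 3 to compound 4 cannot be read. The compounds shown leave open how 4-chloro-3-(trifluoromethyl)phenyl in place of 4-methylphenyl shifts inhibition, in size or direction.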